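Opening the piperazin-1-yl amide of compound 3

The compounds below may be only part of what the source reports. "The series", "measured", "known", "first", "only" and "open" are said of these compounds alone.

Measured in an assay on HEK293 cells for displacement of a labelled ligand from NPC1-like intracellular cholesterol transporter 1 (Homo sapiens) (a lower number here means a stronger inhibitor, a higher number a weaker inhibitor), so far:
compound 1 `CC(C)(C)OC(=O)NCC1CCCN(C(=O)CN2CN(c3ccccc3)C3(CCN(C(=O)c4ccc(C5CCCCC5)cc4)CC3)C2=O)C1`: 3800 nM
compound 2 `CC(C)(C)OC(=O)NC1CCCN(C(=O)CN2CN(c3ccccc3)C3(CCN(C(=O)c4ccc(C5CCCCC5)cc4)CC3)C2=O)C1`: 4400 nM
compound 3 `CC(C)(C)c1ccc(C(=O)N2CCC3(CC2)C(=O)N(CC(=O)N2CCNCC2)CN3c2ccccc2)cc1`: 22000 nM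

Compound 3 gives the highest of the three numbers; compound 2 is nearest and compound 1 furthest, both gaps beyond the scatter. Compound 4 `CC(C)(C)c1ccc(C(=O)N2CCC3(CC2)C(=O)N(CC(=O)NCCN)CN3c2ccccc2)cc1` differs from compound 3 by (2-aminoethyl)amino in place of piperazin-1-yl on a carbonyl carbon. For the measured compounds named here, the one measured step, a 1.2-fold higher number from compound 1 to compound 2 (0.06 log units; within the scatter), concerns a saturated ring carbon in a different part of the molecule, so no measured step speaks to a change on this carbonyl carbon. With nothing to point either way, the expected step of a 1.1-fold lower number from compound 3 to compound 4 (0.04 log units; within the scatter) is none beyond the scatter. Compound 4 is therefore estimated at 20000 nM in this assay, within 7000 nM to 60000 nM, the range kept wide for want of a bearing step.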

Compound 4, half-maximal inhibitory concentration: 7000 nM
Compound 4: middle estimate off by 2.9-fold (0.46 log units), on the high side; the range from low to high includes it.
By their numbers in this assay, from the lowest: compounds 1, 2 and 4 (each within the scatter of the next); then compound 3.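

In this assay, for the compounds shown here, the group on this carbonyl carbon is the first place where a single change moves the number beyond the scatter: (2-aminoethyl)amino in place of piperazin-1-yl gives a 3.1-fold lower number from compound 3 to compound 4 (0.50 log units; beyond the scatter). The closed piperazin-1-yl ring is thus not required for the inhibition seen at this position. Nothing measured here gives a reason for this step.

Still open, going by these compounds, is whether the terminal amine of the chain matters, as against a hydroxyl in its place. A longer chain or a methyl on that amine could also shift the number either way.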